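This account rests on a few compounds, and the source may have more. Where it says the series, first, only, none or still open, it means among the compounds named here.

Measured so far:
- compound 1, `CCCc1nc(C(F)(F)F)ccc1CNC(=O)C(C)c1ccc(NS(C)(=O)=O)c(F)c1`; in an assay on CHO cells for antagonist activity at transient receptor potential cation channel subfamily V member 1 (Homo sapiens), read by FLIPR and calcium flux (a higher number here means a weaker inhibitor, a lower number a stronger inhibitor), compound 1 gives 22.7 nM.
- compound 2, `CCC1CCC(c2nc(C(F)(F)F)ccc2CNC(=O)C(C)c2ccc(NS(C)(=O)=O)c(F)c2)CC1`; in this assay compound 2 gives 0.3 nM.

Within the data shown here, compound 2 stands at the lower of the two numbers so far in this assay. Among the measured compounds shown here, the one measured step is a 76-fold lower number from compound 1 to compound 2 (1.88 log units; beyond the scatter), a large change that lies well beyond the scatter.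

Compound 3, `CC(C(=O)NCc1ccc(C(F)(F)F)nc1C1CCC(C)(C)CC1)c1ccc(NS(C)(=O)=O)c(F)c1`, is not yet measured. It differs from compound 2 in one place: 4,4-dimethylcyclohexyl in place of 4-ethylcyclohexyl on an aromatic carbon. For the measured compounds named here, no measured step bears directly on this exchange. Going by the values given here, the only step available replaces propyl with 4-ethylcyclohexyl and says nothing about moving between two cyclohexyl groups that carry the same number of carbons but differ in how those carbons are arranged. Since the ring itself is kept, no step beyond the scatter is expected in this assay here. The expected step from compound 2 to compound 3 is a 1.7-fold higher number from compound 2 to compound 3 (0.22 log units; within the scatter). Compound 3 is therefore estimated at 0.5 nM, with a range from 0.15 nM to 2 nM.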

Compound 3, inhibition constant: 0.4 nM
Compound 3: the middle estimate sits 1.3-fold (0.10 log units) above what was measured, and the stated range covers the measured number.
By their numbers in this assay, from the lowest: compounds 2 and 3 (each within the scatter of the next); then compound 1.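

At the aromatic carbon next to the ring nitrogen, 4,4-dimethylcyclohexyl in place of 4-ethylcyclohexyl gives, in this assay (a 1.3-fold higher number from compound 2 to compound 3 (0.12 log units; within the scatter)). The two groups hold the same atoms joined differently, so this exchange shows that, for these two substituents, the arrangement of the carbons on the ring makes no difference that this read-out can resolve. The large drop from propyl is also no longer tied to a single cyclohexyl group: alongside the earlier step (a 76-fold lower number from compound 1 to compound 2 (1.88 log units; beyond the scatter)), the new one (a 57-fold lower number from compound 1 to compound 3 (1.75 log units; beyond the scatter)) shows it with both ring substituents, and nothing available explains either the match between the two cyclohexyl compounds or their distance from compound 1.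

Still open, as far as these compounds go, is how much of the drop belongs to the ring and how much to its alkyl substituents, which unsubstituted cyclohexyl, cyclopentyl or phenyl at this carbon would help to separate. Also open, from the compounds shown here alone, is whether the position accepts heteroatoms in the ring, as a piperidine amine or a tetrahydropyran ether would test.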